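The source may report more compounds than this note shows. Statements on the series, on what has been measured and on what is new or still open speak of the compounds shown alone.

In a functional assay on A2780 cells (Homo sapiens) for inhibition (a higher number here means a weaker inhibitor, a lower number a stronger inhibitor), compound 1 (`CC(C(=O)Nc1cc(C2CC2)[nH]n1)c1ccc(N2CCNC2=O)cc1`) gives 2250 nM and compound 2 (`CC(C(=O)Nc1cc(C2CC2)[nH]n1)c1ccc(N2CCCC2)cc1`) gives 370 nM, so compound 2 holds the lower of the two numbers. Compound 3 (`CC(C(=O)Nc1cc(C2CC2)[nH]n1)c1ccc(N2CCCS2(=O)=O)cc1`) differs from compound 2 on the aromatic carbon: a group of 7 heavy atoms (3 carbon, 1 nitrogen, 2 oxygen, 1 sulfur; one five-membered non-aromatic ring with 2 hetero atoms) in place of a group of 5 heavy atoms (4 carbon, 1 nitrogen; one five-membered non-aromatic ring with 1 hetero atom), on an aromatic carbon. Within the data shown here, the one measured step that bears on this is a 6.1-fold lower number from compound 1 to compound 2 (0.78 log units; beyond the scatter), in which pyrrolidin-1-yl entered in place of 2-oxoimidazolidin-1-yl. Here pyrrolidin-1-yl leaves instead, so a higher number of similar size is expected, beyond the scatter. The expected change is a 3.5-fold higher number from compound 2 to compound 3 (0.55 log units; beyond the scatter). For compound 3 the estimated value is 1300 nM, with an expected range of 400 nM to 4000 nM.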

Compound 3, half-maximal inhibitory concentration: 5240 nM
The estimate for compound 3 lay 4.0-fold (0.61 log units) below the measured number, and the stated range ends below it.
By their numbers in this assay, from the lowest: compound 2; then compound 1; then compound 3.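

In this assay this position on the aromatic carbon proves more sensitive than the earlier pair suggested, with a 14-fold higher number from compound 2 to compound 3 (1.15 log units; beyond the scatter) exceeding the size of a 6.1-fold lower number from compound 1 to compound 2 (0.78 log units; beyond the scatter) in the earlier step. The new ring also falls behind 2-oxoimidazolidin-1-yl, with a 2.3-fold higher number from compound 1 to compound 3 (0.37 log units; beyond the scatter) as the second new step, so both rings with 2 hetero atoms give higher numbers than pyrrolidin-1-yl. Nothing available explains these differences. As far as these compounds go, it remains open whether piperidin-1-yl or an open-chain dimethylamino group would match or improve on pyrrolidin-1-yl at this position.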